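The source may hold more compounds than are shown below. What is called first, only, known or untested is meant among the compounds shown, and "the series" means these compounds.

In an assay for activation of potassium voltage-gated channel subfamily KQT member 1 (Cavia porcellus) (on this read-out higher numbers stand for weaker inhibition and lower numbers for stronger inhibition), three compounds already carry numbers. Compound 1 `CCCCCCOc1ccc(C(=O)NCC2CCCC(C)(C)C2)cc1` gives 370 nM, compound 2 `CCCCCCOc1ccc(C(=O)NCCN(CC)CC)cc1` gives 3500 nM, and compound 3 `Cc1noc(-c2ccc(C(=O)NCC3CCCC3(C)C)cc2)n1` gives 580 nM; 220 nM (2 entries). Compound 2 therefore stands at the highest of the two single numbers; its nearest neighbour is compound 1, reached by a 9.5-fold higher number from compound 1 to compound 2 (0.98 log units; beyond the scatter). The repeat entries of compound 3 the several entries of compound 3 in this assay, 580 nM; 220 nM (2 entries) show how far two readings of the same compound can sit apart in this assay.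

Compound 4 `CCCCCCOc1ccc(C(=O)NC2CCC(C)(C)C2)cc1` has not been measured. It differs from compound 2 by 3,3-dimethylcyclopentyl in place of 2-(diethylamino)ethyl on an amide-type nitrogen. Within the data shown here, the one measured step that bears on this change is a 9.5-fold higher number from compound 1 to compound 2 (0.98 log units; beyond the scatter), which runs in the opposite direction: replacing a dimethyl-substituted carbocycle with a diethylamino chain raised the number clearly beyond the scatter. Reversing that kind of exchange should lower the number for compound 4 by a comparable amount, though the ring here sits directly on the amide-type nitrogen and is five-membered, so the size is uncertain.

The estimate for compound 4 is 450 nM, with a range from 150 nM to 1400 nM. The expected step is a 7.8-fold lower number from compound 2 to compound 4 (0.89 log units; beyond the scatter).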

Compound 4, half-maximal inhibitory concentration: 360 nM
Estimate against measurement, compound 4: 1.3-fold (0.10 log units) above; the measured number falls inside the stated range.
By their numbers in this assay, from the lowest: compounds 4 and 1 (each within the scatter of the next); then compound 2.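

The exchange of 2-(diethylamino)ethyl for 3,3-dimethylcyclopentyl on the amide-type nitrogen gives a 9.7-fold lower number from compound 2 to compound 4 (0.99 log units; beyond the scatter) in this assay, so the earlier drop seen with a carbocycle also appears when the ring sits directly on that nitrogen. Compound 1 at 370 nM and compound 4 at 360 nM lie within the scatter of each other, so the two ring-bearing substituents are not separated in this assay. Small gaps in this assay should be read with caution, as readings of one compound can themselves sit apart: the several entries of compound 3 in this assay, 580 nM; 220 nM (2 entries)

The compounds shown leave open how a primary amine, a carboxylic acid or a longer unbranched carbon chain on this nitrogen would read. They also leave open whether the same exchange would run the same way on the core of compound 3.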